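A few compounds are considered here, and "the series" means these few. Any claim that something is new, unique, unknown or untested is made for them only; others in the source may bear on it.

Compound 1 `COc1cc(OC)c(-c2coc3cc(OCC=C(C)C)ccc3c2=O)cc1OC` gives 280 nM in a functional assay on HepG2 cells (Homo sapiens) for antiproliferative activity, read by MTT assay, with a stated time of 24 h; a higher number here means a weaker inhibitor, a lower number a stronger inhibitor. Compound 2 `COc1ccc2c(=O)c(-c3cc(OC)c(OC)cc3OC)coc2c1` gives 2040 nM in this assay.

Compound 2 stands highest of the two numbers in this assay; its nearest neighbour is compound 1, separated by a 7.3-fold higher number from compound 1 to compound 2 (0.86 log units; beyond the scatter). Compound 3 `COc1cc(OC)c(-c2coc3cc(OCc4ccc(C(F)(F)F)cc4)ccc3c2=O)cc1OC` differs from compound 2 by 4-(trifluoromethyl)phenyl in place of hydrogen on a saturated chain carbon bound to an oxygen on an aromatic ring. For the measured compounds named here, the one measured step bearing on this change is a 7.3-fold higher number from compound 1 to compound 2 (0.86 log units; beyond the scatter), where a group on the same chain carbon was replaced by hydrogen and inhibition weakened; putting a group back there is expected to move the number down. Compound 3 is therefore expected to give 350 nM in this assay, within 120 nM to 1000 nM. The expected step is a 5.8-fold lower number from compound 2 to compound 3 (0.77 log units; beyond the scatter).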

Compound 3, half-maximal inhibitory concentration: 890 nM
Compound 3: the middle estimate sits 2.5-fold (0.41 log units) below what was measured; the range from low to high includes it.
By their numbers in this assay, from the lowest: compound 1; then compound 3; then compound 2.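

The result shows that a second, quite different group on this saturated chain carbon also lowers the number in this assay: 4-(trifluoromethyl)phenyl in place of hydrogen gives a 2.3-fold lower number from compound 2 to compound 3 (0.36 log units; beyond the scatter) and so keeps part of the drop. The two groups are not equivalent here, since 4-(trifluoromethyl)phenyl in place of 2-methylprop-1-en-1-yl gives a 3.2-fold higher number from compound 1 to compound 3 (0.50 log units; beyond the scatter) and leaves this compound weaker than the compound carrying the 2-methylprop-1-en-1-yl group. Nothing available explains this difference between the two groups.

The compounds shown leave open whether an unsubstituted benzyl, or a chain ending in an amine or a carboxylic acid, in place of the 4-(trifluoromethyl)benzyl group would fall nearer compound 1 or compound 2.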